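A few compounds are considered here, and "the series" means these few. Any claim that something is new, unique, unknown or untested is made for them only; others in the source may bear on it.

Of the compounds shown here, three built on one shared core have been tested in a functional assay on SF-539 cells (Homo sapiens) for inhibition, read by sulforhodamine B assay, with a stated time of 48 h; a higher number here means a weaker inhibitor of growth, a lower number a stronger inhibitor of growth. Compound 1 `COc1ccc(-c2cc(-c3cccn3C)c(C#N)c(=O)[nH]2)cc1OC` reaches only a limit of the assay, > 100000 nM, in this assay. Compound 2 `COc1ccc(-c2cc(-c3cccn3C)c(C#N)c(N)n2)cc1OC` gives 83200 nM in this assay. Compound 3 `Cn1cccc1-c1cc(-c2cccs2)[nH]c(=O)c1C#N`, the starting point of this step, likewise reaches only a limit of the assay, > 100000 nM, in this assay. Compound 3 therefore stands at the edge of what this assay can report, a position it shares with one other compound, as the limit of > 100000 nM in this assay, at which 2 of the 3 values shown sit, shows, so no order among the three can be drawn from these numbers. Compound 4 `Cn1cccc1-c1cc(-c2ccccc2)[nH]c(=O)c1C#N` is the compound still to be measured, and it differs from compound 3 in one place: phenyl in place of thiophen-2-yl on an aromatic carbon. Among the compounds with values here, no measured pair of compounds differs in just this place, so no measured step exists to guide the expectation. Because compound 3 gives > 100000 nM in this assay, compound 4 is expected to stay weak as well. The expected step from compound 3 to compound 4 is a number no higher from compound 3 to compound 4 (the limit leaves the size open), a change of no meaning beyond scatter. Compound 4 is expected to give about 100000 nM in this assay, within a range of 40000 nM to 300000 nM.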

Compound 4, concentration for 50% growth inhibition: > 100000 nM
Compound 4: a limit, no number; the forecaster's own chance of this, stated with the estimate: 70%; the middle value sits exactly at the limit.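

Within the data shown here, compound 3 and compound 4 both stop at the same limit in this assay, not at a number, so no step between them can be read: the limit of > 100000 nM in this assay, at which 3 of the 4 values shown sit. The compounds shown leave open whether thiophen-2-yl or phenyl in this place gives the stronger inhibitor of growth.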